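The compounds below may be only part of what the source reports. "The series", "measured", "known", "first", "only" and "open" are said of these compounds alone.

Compound 1 `COc1ccc(-c2cc(/C=C/C(=O)c3ccc(N)cc3)[nH]n2)cc1` and compound 2 `COc1cc(-c2cc(/C=C/C(=O)c3ccc(Cl)c(Cl)c3)[nH]n2)cc(OC)c1OC` share one core and differ in their outer rings. In a functional assay on SW-620 cells (Homo sapiens) for cytotoxicity, read by sulforhodamine B assay, with a stated time of 48 h, tested at 0.1 uM (on this read-out lower numbers stand for a stronger effect and higher numbers for a weaker effect at the one concentration tested), compound 1 gives 101%, and compound 2 gives 99%; the two numbers lie within the usual scatter of each other, so neither stands apart from the other. Compound 3 `COc1ccc(C(=O)/C=C/c2cc(-c3cc(OC)c(OC)c(OC)c3)n[nH]2)cc1` has not been measured. It differs from compound 2 in one place: 4-methoxyphenyl in place of 3,4-dichlorophenyl on a carbonyl carbon. Among the compounds with values here, no comparable step among the measured compounds exists, and the step in this assay is expected to be no change at the digits printed from compound 2 to compound 3 (within the scatter), none beyond the scatter. Compound 3 is therefore estimated at 99%, within a range from 90% to 106%.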

Compound 3, a percentage reported as activity, at one concentration (the size of the read-out at that concentration, not a potency): 97%
Estimate against measurement, compound 3: 2 percentage points above; the measured number falls inside the stated range.
By their numbers in this assay, from the lowest: compounds 3, 2 and 1 (each within the scatter of the next).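

In this assay, within the data shown here, putting 4-methoxyphenyl in place of 3,4-dichlorophenyl on a carbonyl carbon gives a number 2 percentage points lower from compound 2 to compound 3 (within the scatter) and thus provides the first readable step at this position. On this read-out, the two aromatic rings are not told apart, although one carries chlorine and the other oxygen. No available evidence bears on this result. Going by these compounds, whether an amine, a carboxylic acid or a longer chain on this carbonyl carbon would give a number beyond the scatter remains open. So does whether these compounds would differ at a higher concentration.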